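Benzyl series: carbamoyl replaced by its sulfur counterpart

The source may hold more compounds than are shown below. What is called first, only, known or untested is meant among the compounds shown, and "the series" means these compounds.

Compound 1 `NC(=O)c1cn(Cc2ccccc2)c2ncnc(N)c12` stands lowest of the three numbers in a functional assay on L1210 cells (Mus musculus) for inhibition (on this read-out higher numbers stand for weaker inhibition and lower numbers for stronger inhibition), where compound 1 gives 16000 nM. Compound 3 `Cn1cc(C(=N)S)c2c(N)ncnc21` comes nearest, giving 38000 nM in this assay; compound 2 `CCCn1cc(C(N)=O)c2c(N)ncnc21` lies furthest, with 73000 nM in this assay. Within the data shown here, the only step measured in one place is a 4.6-fold higher number from compound 1 to compound 2 (0.66 log units; beyond the scatter), and it concerns the chain on the aromatic nitrogen, not the group on the five-membered ring carbon.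

Compound 4 `NC(=S)c1cn(Cc2ccccc2)c2ncnc(N)c12` differs from compound 1 elsewhere: a group of 3 heavy atoms (1 carbon, 1 nitrogen, 1 sulfur; no ring) in place of a group of 3 heavy atoms (1 carbon, 1 nitrogen, 1 oxygen; no ring), on an aromatic carbon. Among the measured compounds shown here, no measured step touches this position, so the direction of the change cannot be taken from the series. Compound 3 carries a sulfur group on the same carbon and a methyl on the nitrogen, but the two values of compound 1 and compound 3 cannot be separated into the two changes. With the count of heavy atoms, donors and acceptors unchanged, the working expectation is a step of no change at the digits printed from compound 1 to compound 4 (within the scatter), inside the scatter. Compound 4 is therefore estimated at 16000 nM, within 5000 nM to 50000 nM.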

Compound 4, half-maximal inhibitory concentration: 70000 nM
The estimate for compound 4 lay 4.4-fold (0.64 log units) below the measured number, and the stated range ends below it.
By their numbers in this assay, from the lowest: compound 1; then compounds 3, 4 and 2 (each within the scatter of the next).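

The position on the aromatic carbon is not indifferent to this exchange: in this assay, putting sulfur in place of the carbamoyl oxygen gives a 4.4-fold higher number from compound 1 to compound 4 (0.64 log units; beyond the scatter), so inhibition is weaker. The counts of heavy atoms, donors and acceptors stay the same, so this step shows that a change of this one atom is enough to move the number beyond the scatter, which the earlier step on the nitrogen chain could not show. No measurement offered here explains the step.

As far as these compounds go, whether the sulfur exchange gives a step of similar size with the chain of compound 2 on the ring nitrogen remains open. Also open, from the compounds shown here alone, is how a nitrile or a carboxylic acid on this carbon would read in this assay.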